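The source may report more compounds than this note shows. Statements on the series, on what has been measured and on what is new or still open speak of the compounds shown alone.

Measured so far:
compound 1 `Clc1ccc(NCc2cn(-c3ccccc3)nc2-c2ccc(Br)cc2)cc1`: > 100000 nM; > 100000 nM (2 entries)
compound 2 `FC(F)(F)c1ccc(NCc2cn(-c3ccccc3)nc2-c2ccc(C(F)(F)F)cc2)cc1`: 27000 nM

In an ADME assay on BHK-21 cells (Mesocricetus auratus) for cytotoxicity, read by MTT assay, with a stated time of 72 h (on this read-out lower numbers stand for higher toxicity in this test and higher numbers for lower toxicity in this test), compound 1 gives > 100000 nM; > 100000 nM (2 entries), which is a limit of the assay and not a number. In this assay, for the measured compounds named here, compound 2 gives 27000 nM, the only number in the set. Compound 3 `FC(F)(F)c1ccc(-c2nn(-c3ccccc3)cc2CNc2ccc(Cl)cc2)cc1` differs from compound 2 by chloro in place of trifluoromethyl on an aromatic carbon. Going by the values given here, no step between measured compounds is available. The change carries compound 3 part way toward compound 1, so a modest expected shift toward lower toxicity is a 1.9-fold higher number from compound 2 to compound 3 (0.27 log units; within the scatter). Compound 3 is expected at 50000 nM, in the range 20000 nM to 120000 nM.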

Compound 3, half-maximal cytotoxic concentration: 31000 nM
Compound 3: the middle estimate sits 1.6-fold (0.21 log units) above what was measured; measured number inside the range.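

In this assay, the exchange of trifluoromethyl for chloro on this aromatic carbon gives a 1.1-fold higher number from compound 2 to compound 3 (0.06 log units; within the scatter), so the two groups cannot be told apart at this position in this read-out. No measured evidence bears on the reason for this result. Compound 1 gives > 100000 nM; > 100000 nM (2 entries), a limit of the assay and not a number.

Still open, going by these compounds, is how an amine or a carboxylic acid on this carbon would read. Also open, on these data alone, is whether the bromo of compound 1, in place of the trifluoromethyl retained in compound 3, accounts for that limit.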